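Extending the amine side chain: dimethyl to diethyl

The source may hold more compounds than are shown below. What is called first, only, known or untested is meant among the compounds shown, and "the series" means these compounds.

Compound 3 `Cc1c(O)c(=O)ccn1CCN(C)C` is measured in a physicochemical assay for acid dissociation, using potentiometric titration, at 9.75. Compound 1 `CCc1c(O)c(=O)ccn1CCN(C)C` gives 9.66 in this assay, and the step of a number 0.09 log units higher from compound 1 to compound 3 (within the scatter) shows that compounds 3 and 1 cannot be told apart. For the measured compounds named here, compound 2 `CCn1ccc(=O)c(O)c1C(C)O` gives 8.74, a number about one unit below compound 3, but it differs from compound 3 in more than one place, so no single step connects the two.

Compound 4 `CCN(CC)CCn1ccc(=O)c(O)c1C` is not yet measured. The change from compound 3 is diethylamino in place of dimethylamino on a saturated chain carbon, two bonds along the chain from an aromatic nitrogen. Going by the values given here, no measured step touches this part of the molecule: the only step in hand, a number 0.09 log units higher from compound 1 to compound 3 (within the scatter), alters the group on the core and stays within the scatter. With nothing pointing either way, compound 4 is expected to stay close to compound 3, with a step of a number 0.05 log units lower from compound 3 to compound 4 (within the scatter) that does not exceed the scatter. Compound 4 is therefore estimated at 9.7 in this assay, within a range from 9.4 to 10.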

Compound 4, acid dissociation constant: 9.65
Beside the measured number, compound 4's estimate is 0.05 log units above it; measured number inside the range.
By their numbers in this assay, from the lowest: compound 2; then compounds 4, 1 and 3 (each within the scatter of the next).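

For the compounds shown here, the swap to diethylamino is the first change at this end of the side chain with a measured result, and in this assay it gives a number 0.10 log units lower from compound 3 to compound 4 (within the scatter). Enlarging the amine on a saturated chain carbon, two bonds along the chain from an aromatic nitrogen, therefore leaves no readable mark on how readily the proton is given up, just as the earlier change on the core gave only a number 0.09 log units higher from compound 1 to compound 3 (within the scatter). No separate measurement is available that could explain this result.

Still open, on these data alone, is whether a ring-closed amine such as piperidine or morpholine in place of diethylamino, or a longer chain carrying the same amine, would also leave the number unchanged. A carboxylic acid at this place could behave differently, and the compounds shown do not settle that either.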